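The source may report more compounds than this note shows. Statements on the series, on what has been measured and on what is new or still open speak of the compounds shown alone.

In a functional assay on NCI-H1975 cells (Homo sapiens) for cytotoxicity, read by MTT assay, with a stated time of 72 h (a higher number here means a weaker inhibitor, a lower number a stronger inhibitor), three compounds have been measured so far. Compound 1 `COc1cc(/C=C2\CN(C)C/C(=C\c3cc(OC)c(OC)c(OC)c3)C2=O)cc(OC)c1OC` gives 1000 nM, the lowest number of the three. Compound 3 `COc1ccc(/C=C2\CN(C)C/C(=C\c3ccc(OC)c(OC)c3)C2=O)cc1OC` gives 6600 nM, and compound 2 `CCCN1C/C(=C\c2ccc(OC)c(OC)c2)C(=O)/C(=C/c2ccc(OC)c(OC)c2)C1` gives 11200 nM. Both of these numbers lie clearly above that of compound 1, which makes it the strongest inhibitor of this small set.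

Compound 4 `COc1cc(/C=C2\CN(C(=O)CCC(=O)O)C/C(=C\c3cc(OC)c(OC)c(OC)c3)C2=O)cc(OC)c1OC` has not been measured yet. It keeps the core of compound 1 and changes one group: (2-carboxyethyl)carbonyl in place of methyl on an amine nitrogen in a ring. Here, (2-carboxyethyl)carbonyl stands in place of methyl on an amine nitrogen in a ring.

For the measured compounds named here, only one measured step involves a change in the group on that nitrogen: a 1.7-fold lower number from compound 2 to compound 3 (0.23 log units; within the scatter). This step stays within the scatter, but it exchanges only a small piece of saturated chain. Going by the values given here, no measured compound carries (2-carboxyethyl)carbonyl, so the data give no direct guide to a change this large. A shift beyond the scatter is therefore possible, and a higher number seems more likely than a lower one, since compound 1 already has the lowest value in the set at 1000 nM. The expected change is a 3.0-fold higher number from compound 1 to compound 4 (0.48 log units; beyond the scatter), with considerable uncertainty. For compound 4 the estimate is 3000 nM, with an expected range from 700 nM to 13000 nM.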

Compound 4, half-maximal inhibitory concentration: > 60000 nM
Compound 4: a limit, no number; the forecaster's own chance of this, stated with the estimate: 10%; at least 20-fold (1.30 log units) between middle value and limit.
By their numbers in this assay, from the lowest: compound 1; then compounds 3 and 2 (each within the scatter of the next). At a limit, above all of these: compound 4.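

Replacing methyl with (2-carboxyethyl)carbonyl on the amine nitrogen in the ring gives an at least 60-fold higher number from compound 1 to compound 4 (1.77 log units; beyond the scatter) in this assay. Compound 4 reads as a limit of the assay, not as a number, so this step has a lower bound but no exact size: the limit of > 60000 nM in this assay, at which 1 of the 4 values shown sits. For the compounds shown here, the only earlier step at this nitrogen, a 1.7-fold lower number from compound 2 to compound 3 (0.23 log units; within the scatter), stayed within the scatter and involved only a saturated chain, whereas this result shows that the group on the nitrogen can matter greatly.

The compounds shown do not tell whether the carbonyl bound to the nitrogen, the carboxylic acid, or the two together account for this large step, and a simple acetyl group or a methyl ester of the acid at the same nitrogen would help to separate these possibilities. They also leave open whether a group carrying an amine, or a longer chain with a carboxylic acid, would behave like compound 4 or stay closer to compound 1.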